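A few compounds are considered here, and "the series" means these few. Any claim that something is new, unique, unknown or untested is made for them only; others in the source may bear on it.

Compound 1, `CCOC(=O)[C@@H](NC(=O)/C=C/c1ccc(O)c(O)c1)[C@@H](C)CC`: 411000 nM
Compound 2, `CCOC(=O)CNC(=O)/C=C/c1ccc(O)c(O)c1`: 340000 nM

In a functional assay, read by spectrophotometry, with a stated time of 1 h (a lower number here means a stronger inhibitor, a higher number a weaker inhibitor), compound 2 gives the lower of the two numbers, but the step between the pair, a 1.2-fold lower number from compound 1 to compound 2 (0.08 log units; within the scatter), lies within the scatter, so compound 2 cannot be called the stronger of the two.

Compound 3, `CCOC(=O)[C@@H](NC(=O)/C=C/c1ccc(O)c(O)c1)C(C)C`, has not yet been measured. It differs from compound 2 by isopropyl in place of hydrogen on a saturated chain carbon bound to an amide-type nitrogen and a carbonyl carbon. For the measured compounds named here, only one measured step bears on this change: the one that removed a sec-butyl group from that same carbon, a 1.2-fold lower number from compound 1 to compound 2 (0.08 log units; within the scatter), which stayed within the scatter. Placing an isopropyl group on the same carbon is a change of the same kind, and no movement beyond the scatter is expected in this assay; for compound 3 the expected step is a 1.1-fold higher number from compound 2 to compound 3 (0.05 log units; within the scatter). Compound 3 is accordingly estimated at 380000 nM, with a likely range from 200000 nM to 720000 nM.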

Compound 3, half-maximal inhibitory concentration: 348000 nM
Estimate against measurement, compound 3: 1.1-fold (0.04 log units) above; the range from low to high includes it.
By their numbers in this assay, from the lowest: compounds 2, 3 and 1 (each within the scatter of the next).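

In this assay, isopropyl in place of hydrogen on a saturated chain carbon bound to an amide-type nitrogen and a carbonyl carbon gives a 1.0-fold higher number from compound 2 to compound 3 (0.01 log units; within the scatter) and so, like sec-butyl, leaves the number within the scatter. Hydrogen in place of methyl on a saturated chain carbon, three bonds along the chain from an amide-type nitrogen and a carbonyl carbon, gives a 1.2-fold lower number from compound 1 to compound 3 (0.07 log units; within the scatter) and is also within the scatter, so hydrogen, isopropyl and sec-butyl at this place cannot be told apart in this read-out. No measurement shown here offers a reason for this.

The compounds shown leave open whether an amine, a carboxylic acid or a longer chain on this carbon would carry the number beyond the scatter. They also leave open whether a change elsewhere on the shared core would do so.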